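A Chlorine Added to the Benzylsulfanyl Group

The source may hold more compounds than are shown below. What is called first, only, known or untested is meant among the compounds shown, and "the series" means these compounds.

Compound 1 `CC1=C(C(=O)Nc2ccc([N+](=O)[O-])cc2)C(c2ccc(Br)cc2)N=C(SCc2ccccc2)N1`: 37.6%
Compound 2 `CC1=C(C(=O)Nc2ccc([N+](=O)[O-])cc2)C(c2cccc([N+](=O)[O-])c2)N=C(SCc2ccccc2)N1`: 32.5%

Of the compounds shown here, two have been measured in a functional assay on the whole organism (artery, strain albino) with Rattus norvegicus as the target, with a stated time of 360 min, at a dose of 10 mg/kg by the oral route; a lower number here means less inhibition, a higher number more inhibition at the dose given (going by the name of the read-out). For the measured compounds named here, compound 2 stands together with compound 1, the two numbers within the usual scatter: the one measured step, a number 5.1 percentage points lower from compound 1 to compound 2 (within the scatter), exchanged the group on the saturated ring carbon and did not move the number beyond the scatter.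

Compound 3 `CC1=C(C(=O)Nc2ccc([N+](=O)[O-])cc2)C(c2cccc([N+](=O)[O-])c2)N=C(SCc2ccc(Cl)cc2)N1` is the next compound. It differs from compound 2 in one place: chloro in place of hydrogen on an aromatic carbon. Going by the values given here, no measured step touches the benzyl group, so nothing on hand shows how this change acts. Among the compounds with values here, the only step known, from compound 1 to compound 2, lay within the scatter and concerned another part of the molecule. With no guide to a shift in either direction, compound 3 is expected to give a number close to compound 2, a step of a number 0.5 percentage points higher from compound 2 to compound 3 (within the scatter), and its estimated inhibition in this assay is 33%, with a range of 18% to 48%.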

Compound 3, a percentage reported as inhibition, in the whole organism at one dose (the size of the read-out at that dose, not a potency): 33%
The estimate for compound 3 equals the measured number at the digits printed, and the stated range covers the measured number.
By their numbers in this assay, from the lowest: compounds 2, 3 and 1 (each within the scatter of the next).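

In this assay, for the compounds shown here, exchanging benzylsulfanyl for (4-chlorobenzyl)sulfanyl gives a number 0.5 percentage points higher from compound 2 to compound 3 (within the scatter) and so offers the first measured look at this part of the molecule. A chloro on this aromatic carbon, para to a large group, does not separate the two compounds, so the number alone cannot tell them apart. No measurement on hand bears on this result.

Going by these compounds, this is a single small group at a single place, so it remains open whether a methoxy group, an amine or a carboxylic acid on the same carbon would give a number beyond the scatter. Also open, on these data alone, is what a longer chain in place of the benzyl group would do, and whether chloro on another carbon of this ring would match this step.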